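Swapping pyridin-2-yl for 3-(trifluoromethyl)phenyl

This account rests on a few compounds, and the source may have more. Where it says the series, first, only, none or still open, it means among the compounds named here.

In a functional assay on HeLa cells (Homo sapiens) for antiproliferative activity, read by MTT assay, with a stated time of 24 h (on this read-out higher numbers stand for weaker inhibition and lower numbers for stronger inhibition), compound 1 `COC(=O)c1scc(-c2ccc(NC(=O)c3ccc4ccccc4c3)cc2)c1OC` gives 18200 nM. Compound 2 `COC(=O)c1scc(-c2ccc(NC(=O)c3ccccn3)cc2)c1OC` sits at the weak end of the numbers shown: its reading of > 50000 nM is a limit and not a number. Compound 3 `COC(=O)c1scc(-c2ccc(NC(=O)c3cccc(C(F)(F)F)c3)cc2)c1OC` has 3-(trifluoromethyl)phenyl in place of pyridin-2-yl on a carbonyl carbon. For the measured compounds named here, only one measured step bears on this place: an at least 2.7-fold higher number from compound 1 to compound 2 (0.43 log units; beyond the scatter), which put pyridin-2-yl where compound 1 has naphthalen-2-yl. Compound 3 also loses pyridin-2-yl, so a move back towards compound 1 seems reasonable, though 3-(trifluoromethyl)phenyl is a different group and the limit hides the true size of that step. The expected change in this assay is a modest one towards stronger inhibition, an at least 2.0-fold lower number from compound 2 to compound 3 (0.31 log units; beyond the scatter). For compound 3 the estimated value is 24000 nM, within an expected range from 9000 nM to 50000 nM.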

Compound 3, half-maximal inhibitory concentration: 19300 nM
Beside the measured number, compound 3's estimate is 1.2-fold (0.09 log units) above it; low and high end bracket the measured number.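

On the carbonyl carbon, this assay now shows an at least 2.5-fold lower number from compound 2 to compound 3 (0.41 log units; beyond the scatter), so replacing pyridin-2-yl does not have to leave a compound at the weak end of the numbers. The second comparison is a 1.1-fold higher number from compound 1 to compound 3 (0.03 log units; within the scatter): 3-(trifluoromethyl)phenyl and naphthalen-2-yl cannot be told apart here, so this position accepts two quite different groups with the same outcome. The reading of compound 2 is a limit and not a number, so the first step gives only a minimum size: the limit of > 50000 nM in this assay, at which 1 of the 3 values shown sits.

Still open, as far as these compounds go, is whether the ring nitrogen of pyridin-2-yl alone accounts for the weak reading, a question that a plain phenyl group at this place would address. An amine or a carboxylic acid on that ring would show whether inhibition stronger than in compound 1 and compound 3 is within reach.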